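This account rests on a few compounds, and the source may have more. Where it says the series, first, only, none or still open, it means among the compounds named here.

In an ADME assay on MT4 cells (Homo sapiens) for cytotoxicity, read by MTT assay, with a stated time of 4 days (a lower number here means that less compound is tolerated, a higher number that more compound is tolerated), the measured compounds gave only limits:

Compound 1 `CCN(CC)c1nc(Cc2c(F)cccc2F)cc(=O)[nH]1` gave the limit > 85000 nM
Compound 2 `Cc1c(Cc2c(F)cccc2F)nc(N(C)C)[nH]c1=O` gave the limit > 89000 nM
Compound 3 `Cc1c(Cc2c(F)cccc2F)nc(N(C)c2ccccc2)[nH]c1=O` gave the limit > 73000 nM

Compound 3 has no number here, only (the limit of > 73000 nM in this assay, at which 1 of the 3 values shown sits), and so it cannot be ranked against the other two compounds. The next compound is compound 4 `CCN(CC)c1nc(Cc2c(F)cccc2F)c(C)c(=O)[nH]1`, and the change leading to it is diethylamino in place of methyl(phenyl)amino on an aromatic carbon. In words, this is diethylamino in place of methyl(phenyl)amino on an aromatic carbon, para to a methyl group.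

Among the compounds with values here, the only measured step at this place is a step that the two limits leave unreadable from compound 2 to compound 3, with phenyl in place of methyl on a nitrogen on an aromatic ring. It gives no size to carry over. The nearest guide to the entering group is compound 1, which also carries diethylamino and whose value is again a limit, > 85000 nM. On this evidence, no step beyond the scatter is expected in this assay, and the estimate amounts to a step that the limit leaves unreadable from compound 3 to compound 4.

For compound 4 the expected value is 85000 nM, with an estimated range from 35000 nM to 150000 nM, and it will most likely be reported as a limit once more.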

Compound 4, half-maximal cytotoxic concentration: > 81000 nM
Compound 4: no number, only a limit; the forecaster's own chance of this, stated with the estimate: 80%; the middle value does not contradict the limit.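

In this assay compound 4 gives > 81000 nM, which is a limit. Within the data shown here, compound 1, compound 2 and compound 3 also have only limits, so no step to compound 4 can be read. The compounds shown leave open where the half-maximal cytotoxic concentration of any of them lies, and whether diethylamino in place of methyl(phenyl)amino, or methyl in place of hydrogen, changes it at all.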